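The source may report more compounds than this note shows. Statements on the series, on what has been measured and on what is new or still open speak of the compounds shown alone.

Measured compounds:
compound 1 `CC1=C(C)C(=O)C(CCCCCCCCCCn2cc(C[C@H](O)COCCOC[C@@H](O)Cc3ccc(-c4ccccc4)cc3)nn2)=C(C)C1=O` gives 900 nM
compound 2 `O[C@H](COCCOC[C@@H](O)Cc1cn(Cc2cccc(-c3ccccc3)c2)nn1)Cc1ccc(-c2ccccc2)cc1` gives 7200 nM
compound 3 `O[C@H](COCCOC[C@@H](O)Cc1c[nH]nn1)Cc1ccc(-c2ccccc2)cc1` gives > 100000 nM

In a functional assay on HCT-116 cells (Homo sapiens) for inhibition, read by MTT assay, with a stated time of 72 h (on this read-out higher numbers stand for weaker inhibition of growth and lower numbers for stronger inhibition of growth), compound 1 gives 900 nM and compound 2 gives 7200 nM. For compound 3 this assay reports only a limit, > 100000 nM, so compound 3 stands at the weak end of the numbers shown, as in the limit of > 100000 nM in this assay, at which 1 of the 3 values shown sits. Compound 4 `O[C@H](COCCOC[C@@H](O)Cc1cn(-c2cncc3ccccc23)nn1)Cc1ccc(-c2ccccc2)cc1` has not been measured. It differs from compound 3 by isoquinolin-4-yl in place of hydrogen on an aromatic nitrogen. Among the measured compounds shown here, no step between measured compounds is available. Compound 2, which also carries a group on an aromatic nitrogen of the shared core, gives 7200 nM. On that ground a step of an at least 8.3-fold lower number from compound 3 to compound 4 (0.92 log units; beyond the scatter) toward stronger inhibition is expected. Compound 4 is expected at 12000 nM, between 3000 nM and 50000 nM.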

Compound 4, concentration for 50% growth inhibition: 17800 nM
Beside the measured number, compound 4's estimate is 1.5-fold (0.17 log units) below it; low and high end bracket the measured number.
By their numbers in this assay, from the lowest: compound 1; then compound 2; then compound 4. At a limit, above all of these: compound 3.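

In this assay, isoquinolin-4-yl in place of hydrogen on an aromatic nitrogen gives an at least 5.6-fold lower number from compound 3 to compound 4 (0.74 log units; beyond the scatter). This shows that a two-ring aromatic group set directly on this nitrogen is enough to bring growth inhibition into a measurable range. The size of the step is only a minimum because the value of compound 3 is a limit: the limit of > 100000 nM in this assay, at which 1 of the 4 values shown sits.

On these data alone, whether the ring nitrogen of isoquinolin-4-yl plays any part remains open, as a naphthyl group would be needed to tell. As far as these compounds go, how a plain phenyl ring, an amine or a carboxylic acid at this position would compare also remains open.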